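The compounds below may be only part of what the source reports. "The series", "measured", "known", "first", "only" and "open" are said of these compounds alone.

compound 1 `COc1ccc2occ(CSC(=S)N3CCCCC3)c(=O)c2c1` — > 40000 nM
compound 2 `COc1ccc2oc(CSC(=S)N3CCCCC3)cc(=O)c2c1` — 10000 nM
compound 3 `O=c1cc(CSC(=S)N2CCOCC2)oc2ccccc12` — 21000 nM

Of the compounds shown here, three have been tested in a functional assay on MCF7 cells (Homo sapiens) for antiproliferative activity, read by MTT assay, with a stated time of 72 h; on this read-out lower numbers stand for stronger inhibition and higher numbers for weaker inhibition. Compound 1, `COc1ccc2occ(CSC(=S)N3CCCCC3)c(=O)c2c1`, gives only a limit of the assay, > 40000 nM, so no number stands for it. Compound 2, `COc1ccc2oc(CSC(=S)N3CCCCC3)cc(=O)c2c1`, gives 10000 nM in this assay. Compound 3, `O=c1cc(CSC(=S)N2CCOCC2)oc2ccccc12`, gives 21000 nM. The values of compound 2 and compound 3 lie within the usual scatter of each other, and neither can be called the stronger. Compound 1 sits at the limit of > 40000 nM in this assay, at which 1 of the 3 values shown sits. Compound 4, `COc1ccc2occ(CSC(=S)N3CCOCC3)c(=O)c2c1`, has not yet been measured. It differs from compound 1 in one place: morpholin-4-yl in place of piperidin-1-yl on a thiocarbonyl carbon. Within the data shown here, no measured pair covers this change alone; compound 3 carries the morpholin-4-yl group and compound 2 the piperidin-1-yl group, but they differ in more than this one place. The step of a number no higher from compound 1 to compound 4 (the limit leaves the size open) is expected to be small, none beyond the scatter. Compound 4 is therefore expected near 40000 nM, between 15000 nM and 100000 nM, and may well again give only a limit.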

Compound 4, half-maximal inhibitory concentration: 11800 nM
For compound 4 the middle estimate is 3.4-fold (0.53 log units) above the measured one; measured number outside the range, below it.
By their numbers in this assay, from the lowest: compounds 2, 4 and 3 (each within the scatter of the next, the first and the last beyond it). At a limit, above all of these: compound 1.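

In this assay, the exchange of piperidin-1-yl for morpholin-4-yl on a thiocarbonyl carbon gives an at least 3.3-fold lower number from compound 1 to compound 4 (0.53 log units; beyond the scatter). Among these compounds, this is the first reading of that exchange alone, since no earlier pair differed in this one place, and it shows that the group at this position can change the read-out beyond the scatter on the core of compound 1. The step has only a lower bound, because compound 1 gives a limit and not a number: the limit of > 40000 nM in this assay, at which 1 of the 4 values shown sits.

The compounds shown leave open how large the step really is and whether the same exchange has a similar effect on the core of compound 2. They also leave open what a piperazin-1-yl ring or an open-chain diethylamino group would give in the same place, on a thiocarbonyl carbon.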